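The source may hold more compounds than are shown below. What is called first, only, known or untested is meant among the compounds shown, and "the series" means these compounds.

In a functional assay on HepG2 cells (Homo sapiens) for inhibition, read by MTT assay (on this read-out higher numbers stand for weaker inhibition and lower numbers for stronger inhibition), compound 1 (`COc1cc2ncnc(Nc3ccc(NC(=O)c4ccccc4C)cc3)c2cc1OC`) gives 15000 nM, compound 2 (`COc1cc2ncnc(Nc3ccc(NC(=O)c4ccc(F)cc4)cc3)c2cc1OC`) gives 15000 nM and compound 3 (`COc1cc2ncnc(Nc3ccc(NC(=O)c4cccc(Cl)c4)cc3)c2cc1OC`) gives 12000 nM, so compound 3 stands level with the other two within the scatter. Still unmeasured is compound 4 (`COc1cc2ncnc(Nc3ccc(NC(=O)c4ccc(Cl)cc4)cc3)c2cc1OC`), which carries 4-chlorophenyl in place of 3-chlorophenyl on a carbonyl carbon. Three measured steps swap the aryl group at this same carbonyl carbon: no change at the digits printed from compound 1 to compound 2 (within the scatter), a 1.3-fold lower number from compound 1 to compound 3 (0.10 log units; within the scatter) and a 1.3-fold lower number from compound 2 to compound 3 (0.10 log units; within the scatter). All three remain within the scatter. Going by the step of a 1.3-fold lower number from compound 2 to compound 3 (0.10 log units; within the scatter), no change beyond the scatter is expected in this assay, in either direction. The estimated step is a 1.2-fold higher number from compound 3 to compound 4 (0.07 log units; within the scatter). For compound 4 the expected value is 14000 nM, with an estimated range of 7000 nM to 28000 nM.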

Compound 4, half-maximal inhibitory concentration: 28000 nM
Estimate against measurement, compound 4: 2.0-fold (0.30 log units) below, and the stated range covers the measured number.
By their numbers in this assay, from the lowest: compounds 3, 1, 2 and 4 (each within the scatter of the next, the first and the last beyond it).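

Swapping 3-chlorophenyl for 4-chlorophenyl on the carbonyl carbon gives the only step among these compounds that lies beyond the scatter in this assay (a 2.3-fold higher number from compound 3 to compound 4 (0.37 log units; beyond the scatter)), so the placing of a single chlorine can register here, if only modestly. The other two steps to compound 4 stay within the scatter (a 1.9-fold higher number from compound 2 to compound 4 (0.27 log units; within the scatter); a 1.9-fold higher number from compound 1 to compound 4 (0.27 log units; within the scatter)). Going by these compounds, whether a methoxy group, an amine or a carboxylic acid on this aryl ring would shift the number further remains open. Nothing at hand accounts for the step between the two chlorophenyl compounds.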